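This account rests on a few compounds, and the source may have more. Where it says the series, first, only, none or still open, it means among the compounds named here.

Compound 1 `Clc1ccc(C2CC(c3ccc(N4CCCCC4)cc3)=NN2c2nc(-c3ccccc3)cs2)cc1` gives 65800 nM in a functional assay on A-375 cells (Homo sapiens) for antiproliferative activity, read by MTT assay, with a stated time of 72 h; a lower number here means a stronger inhibitor, a higher number a weaker inhibitor. Compound 2 `COc1ccc(-c2csc(N3N=C(c4ccc(N5CCCCC5)cc4)CC3c3ccc(Cl)cc3)n2)cc1` sits at the limit of > 100000 nM in this assay, at which 1 of the 2 values shown sits, an assay limit rather than a number. In this assay compound 2 therefore shows only > 100000 nM, a limit. Among the compounds with values here, the one step measured so far is an at least 1.5-fold higher number from compound 1 to compound 2 (0.18 log units; that floor lies within the scatter), whose floor lies within the scatter. Compound 3 `Clc1ccc(C2CC(c3ccc(N4CCCCC4)cc3)=NN2c2nc(-c3ccc4ccccc4c3)cs2)cc1` differs from compound 2 by naphthalen-2-yl in place of 4-methoxyphenyl on an aromatic carbon. Within the data shown here, no measured step covers an aryl-to-naphthyl exchange, and the methoxy step gives no direction beyond scatter, so no change beyond the scatter is expected in this assay. Compound 3 is expected near 80000 nM, between 30000 nM and 200000 nM. The expected step is an at least 1.2-fold lower number from compound 2 to compound 3 (0.09 log units; that floor lies within the scatter).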

Compound 3, half-maximal inhibitory concentration: > 100000 nM
Compound 3: only a limit was reported; the forecaster's own chance of this, stated with the estimate: 45%; middle value at least 1.2-fold (0.09 log units) from the limit.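

In this assay, naphthalen-2-yl in place of phenyl on this aromatic carbon gives an at least 1.5-fold higher number from compound 1 to compound 3 (0.18 log units; that floor lies within the scatter), so a second aryl exchange here also shows no change beyond the scatter. The step between compound 2 and compound 3 cannot be read because both values are limits: the limit of > 100000 nM in this assay, at which 2 of the 3 values shown sit.

Open, as far as these compounds go, is whether an amine or a carboxylic acid on this aromatic carbon would give a clearly lower number than compound 1 at 65800 nM. From the compounds shown here alone, how the 4-methoxyphenyl and naphthalen-2-yl groups rank against each other also stays open.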